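The source may hold more compounds than are shown below. What is called first, only, known or untested is meant among the compounds shown, and "the series" means these compounds.

Cytotoxicity notes on the series. Compound 1 `O=C(c1ccc(NCc2cncn2Cc2ccc(-c3ccccc3)cc2)cc1-c1ccccc1)N1CCCCC1` carries a (piperidin-1-yl)carbonyl on the shared core. In a toxicity assay on NIH3T3 cells (Mus musculus) for cytotoxicity, read by resazurin assay (on this read-out higher numbers stand for an effect only at larger amounts of compound and lower numbers for an effect already at smaller amounts), compound 1 gives > 1000 nM, which is a limit of the assay and not a number. Compound 3 `Cc1ccccc1-c1cccc(NCc2cncn2Cc2ccccc2)c1` gives > 1000 nM in this assay, again a limit rather than a number. For compound 2 `COC(=O)c1ccc(NCc2cncn2Cc2ccccc2F)cc1-c1ccccc1` the entry in this assay reads "not determined" (no result reported). Compound 1 therefore stands where the measured set as a whole stands: two of the three values sit at the limit of > 1000 nM in this assay, at which 2 of the 3 values shown sit, and the third carries no number, so no ordering among the three can be read.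

Compound 4 `CCOC(=O)c1ccc(NCc2cncn2Cc2ccc(-c3ccccc3)cc2)cc1-c1ccccc1` is not yet measured. Its change from compound 1 is ethoxy in place of piperidin-1-yl on a carbonyl carbon, the (piperidin-1-yl)carbonyl becoming ethoxycarbonyl. Among the compounds with values here, no step between measured compounds is available, so the size of this one rests on expectation alone. The step is expected to be a step that the limit leaves unreadable from compound 1 to compound 4, nothing beyond the scatter. Compound 4 is expected at 2000 nM, with a range from 700 nM to 8000 nM. Because compound 1 and compound 3 both sit at the limit of > 1000 nM in this assay, at which 2 of the 3 values shown sit, the most likely outcome is that compound 4 again returns only a limit in this assay.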

Compound 4, half-maximal effective concentration: > 10000 nM
Compound 4: no number, only a limit; the forecaster's own chance of this, stated with the estimate: 70%; at least 5.0-fold (0.69 log units) between middle value and limit.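

Compound 4 gives > 10000 nM in this assay, which is a limit and not a number. Within the data shown here, compound 1 also stands only at a limit, so no step from compound 1 to compound 4 can be read. The compounds shown leave open where the half-maximal effective concentration of either compound lies, and whether the ethoxy and piperidin-1-yl compounds differ at all.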